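A few compounds are considered here, and "the series" means these few. Any claim that something is new, unique, unknown or untested is made for them only; others in the source may bear on it.

Measured in this series:
compound 1 `C[C@@H]1CCCN1c1c(C#N)c2c(N)nc(Nc3cn[nH]c3)nc2n1C` — 6 nM
compound 2 `Cc1c(Nc2nc(N)c3c(C#N)c(N4CCC[C@H]4C)n(C)c3n2)cnn1[C@H]1CCOC1` — 14 nM
compound 3 `C[C@@H]1CCCN1c1c(C#N)c2c(N)nc(Nc3ccn(C)n3)cc2n1C` — 206 nM

In an assay on isolated protein for inhibition of Leucine-rich repeat serine/threonine-protein kinase 2 variant G2019S (Homo sapiens), read by TR-FRET and LanthaScreen, with stated times of 50 min and 30 min, in the presence of a further agent that is not named here (on this read-out higher numbers stand for weaker inhibition and lower numbers for stronger inhibition), compound 1 gives 6 nM, the lowest of the three numbers. Compound 2 gives 14 nM, a gap beyond the scatter. Compound 3 gives 206 nM, the furthest from compound 1 and well beyond the scatter; compound 3 also differs in more than one place from the others, so its number is read on its own.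

Compound 4 `C[C@@H]1CCCN1c1c(C#N)c2c(N)nc(Nc3cnn(C)c3)nc2n1C` differs from compound 1 by methyl in place of hydrogen on an aromatic nitrogen. Going by the values given here, no pair of measured compounds carries this exact change. Compound 2 bears a substituent on an aromatic nitrogen of the same kind of five-membered ring and stays within a modest distance of compound 1 in this assay, which is the nearest guide. The expectation for compound 4 is therefore a small move toward a higher number, close to or only slightly beyond the scatter, as a 1.7-fold higher number from compound 1 to compound 4 (0.22 log units; within the scatter). Compound 4 is estimated at 10 nM, with a range from 4 nM to 28 nM.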

Compound 4, half-maximal inhibitory concentration: 5 nM
Compound 4: middle estimate off by 2.0-fold (0.30 log units), on the high side; measured number inside the range.
By their numbers in this assay, from the lowest: compounds 4 and 1 (each within the scatter of the next); then compound 2; then compound 3.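

The step of a 1.2-fold lower number from compound 1 to compound 4 (0.08 log units; within the scatter) in this assay is the series' only comparison that differs in one place, and it lies within the scatter. Compound 1 and compound 4 therefore cannot be told apart, so the hydrogen on this aromatic nitrogen is not needed for a number at this level, and methyl is accepted there. Nothing available here accounts for this result.

Going by these compounds, how a group larger than methyl on the same nitrogen would read remains open, for example an ethyl, a longer chain or a chain ending in an amine or a carboxylic acid. Compound 2 carries a larger group on a nitrogen of this kind of ring, but it differs from compound 4 in more than one place, so it gives no answer.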